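The source may hold more compounds than are shown below. What is called first, only, known or untested is meant among the compounds shown, and "the series" means these compounds.

Of the compounds shown here, three have so far been measured in an assay on NK92 cells for inhibition of interleukin-15 (Homo sapiens), read by AlphaScreen, with stated times of 30 min and 1 h; a higher number here means a weaker inhibitor, a lower number a stronger inhibitor. Compound 1 `Cn1c(Cc2nn(C)c(=O)c3ccccc23)nnc1SCCCCCCCC(=O)Nc1ccc(Cl)cc1Cl` gives 190 nM, compound 2 `CCOC(CCn1c(Cc2nn(C)c(=O)c3ccccc23)nnc1SCCCCCCCC(=O)Nc1ccc(Cl)cc1Cl)OCC` gives 30000 nM, and compound 3 `Cn1nc(Cc2nnc(SCCCCCCCC(=O)Nc3ccc(Cl)cc3Cl)n2CCC=O)c2ccccc2c1=O` gives 710 nM, which is the second highest of the three numbers, well apart from both neighbours. Compound 4 `Cn1nc(Cc2nnc(SCCCCCCCC(=O)Nc3ccc(Cl)cc3Cl)[nH]2)c2ccccc2c1=O` differs from compound 3 by hydrogen in place of 2-formylethyl on an aromatic nitrogen. Among the measured compounds shown here, two measured steps bear on this change: a 3.7-fold higher number from compound 1 to compound 3 (0.57 log units; beyond the scatter), and a 160-fold higher number from compound 1 to compound 2 (2.20 log units; beyond the scatter); in both the number rose as the group on that chain carbon grew. Taking the chain away entirely goes further than compound 1 in the same direction, so a lower number is expected for compound 4, with the step estimated at a 2.4-fold lower number from compound 3 to compound 4 (0.37 log units; beyond the scatter). Compound 4 is therefore expected to give about 300 nM in this assay, within a range of 100 nM to 1000 nM.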

Compound 4, half-maximal inhibitory concentration: 280 nM
Beside the measured number, compound 4's estimate is 1.1-fold (0.03 log units) above it, within the range that was stated.
By their numbers in this assay, from the lowest: compounds 1 and 4 (each within the scatter of the next); then compound 3; then compound 2.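

In this assay, taking away 2-formylethyl gives a 2.5-fold lower number from compound 3 to compound 4 (0.40 log units; beyond the scatter) and taking away the larger chain gives a 110-fold lower number from compound 2 to compound 4 (2.03 log units; beyond the scatter) so among these compounds both chains on the aromatic nitrogen carry a higher number than hydrogen does. Hydrogen and methyl cannot be told apart here, with a 1.5-fold higher number from compound 1 to compound 4 (0.17 log units; within the scatter) so this nitrogen needs no carbon group to reach this level of inhibition. Nothing given explains these differences. Still open, as far as these compounds go, is whether a plain propyl chain behaves like 2-formylethyl. From the compounds shown here alone, an amine or a carboxylic acid at the end of that chain also remains untested in these compounds.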